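Swapping a ring for a chain in a cytotoxicity screen

The compounds below may be only part of what the source reports. "The series", "measured", "known", "first", "only" and "open" are said of these compounds alone.

compound 1 `CCCCCCCCCO[C@@H]1[C@@H](N)[C@@H](O[C@H]2[C@H](O)[C@@H](O)[C@H](N)C[C@@H]2N)O[C@H](CN)[C@H]1OCCCCCCCCC`: 82.7%
compound 2 `C=CCO[C@H]1O[C@H](CN)[C@@H](O)[C@H](O)[C@H]1N`: 82.2%
compound 3 `NC[C@H]1O[C@H](O[C@H]2[C@H](O)[C@@H](O)[C@H](N)C[C@@H]2N)[C@H](N)[C@@H](OCCCc2ccc3ccccc3c2)[C@@H]1OCCCc1ccc2ccccc2c1`: 87.7%

All three measured compounds were tested in a toxicity assay on the whole organism (J774 cells) for cytotoxicity, with Mus musculus as the target, read by MTT assay, with a stated time of 24 h, tested at 10 uM; on this read-out higher numbers stand for a weaker effect at the one concentration tested and lower numbers for a stronger effect. Compound 1 stands second highest of the three numbers: compound 2 sits a little lower and compound 3 a little higher, and both gaps fall within the usual scatter of repeated measurements, so the three read alike and none can be set apart from the others. No two of them differ in only one place, so no single structural step can be read from the measured set.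

Compound 4 `CCCCCCCCCO[C@@H]1[C@@H](N)[C@@H](OCC(O)CNCCN)O[C@H](CN)[C@H]1OCCCCCCCCC` has not been measured. It derives from compound 1 by one change (3-((2-aminoethyl)amino)-2-hydroxypropyl in place of 4,6-diamino-2,3-dihydroxycyclohexyl on an oxygen on a saturated carbon), with the rest of compound 1 unchanged.

Going by the values given here, with no measured step to lean on, the expectation rests on how flat the three measured values are. The change from compound 1 to compound 4 is expected to give a number 0.7 percentage points lower from compound 1 to compound 4 (within the scatter), that is, no step beyond the scatter. Compound 4 is therefore estimated at 82%, within a range from 68% to 93%.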

Compound 4, a percentage reported as activity, at one concentration (the size of the read-out at that concentration, not a potency): 87.5%
Estimate against measurement, compound 4: 5.5 percentage points below; low and high end bracket the measured number.
By their numbers in this assay, from the lowest: compounds 2, 1, 4 and 3 (each within the scatter of the next).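

Going by these compounds alone, the step is the first measured change at this position: in this assay the open-chain 3-((2-aminoethyl)amino)-2-hydroxypropyl group in place of the 4,6-diamino-2,3-dihydroxycyclohexyl group on the oxygen gives a small shift (a number 4.8 percentage points higher from compound 1 to compound 4 (within the scatter)). On the core of compound 1, then, this ring can give way to a chain with no ring and fewer heavy atoms, hydrogen-bond donors and acceptors without a step beyond the usual scatter at the one concentration tested. No measurement shown links this result to any feature of either group.

Still open, going by these compounds, is whether a different group on the same oxygen, such as a longer chain ending in a carboxylic acid or a plain hexyl chain with no amine, would give a step beyond the scatter. Also open, on these data alone, is whether the same swap reads alike on the core of compound 3.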